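Shortening the chloropropyl tail of a sulfonate urea

The compounds below may be only part of what the source reports. "The series", "measured", "known", "first", "only" and "open" are said of these compounds alone.

Compound 1 `CCCc1ccccc1OS(=O)(=O)c1cccc(NC(=O)NCCCCl)c1`: 14000 nM
Compound 2 `O=C(NCCCCl)Nc1cccc(S(=O)(=O)Oc2ccc(O)cc2)c1`: 51000 nM

Of the compounds shown here, two have been measured in a functional assay on HT-29 cells (Homo sapiens) for cytotoxicity, read by sulforhodamine B assay, with a stated time of 48 h; a lower number here means a stronger inhibitor, a higher number a weaker inhibitor. Compound 1 gives the lowest of the two numbers, and its nearest neighbour is compound 2, reached by a 3.6-fold higher number from compound 1 to compound 2 (0.56 log units; beyond the scatter), a change at the oxygen-bound ring only.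

Compound 3 `CCCc1ccccc1OS(=O)(=O)c1cccc(NC(=O)NCC)c1` keeps the ring of compound 1 and changes the other end instead: hydrogen in place of chloromethyl on a saturated chain carbon, two bonds along the chain from an amide-type nitrogen. Among the compounds with values here, no measured step touches this tail; the only step known, the one between compound 1 and compound 2, lies on the far side of the shared core and therefore says nothing direct about what losing the chloromethyl should do. The expectation must rest on compound 1 alone, with a wide margin. Since the change removes part of the chain that carries the only halogen, a weaker result than compound 1 is expected, though the data cannot rule out little change; the step from compound 1 is estimated as a 2.1-fold higher number from compound 1 to compound 3 (0.33 log units; beyond the scatter). For compound 3 in this assay the estimate is 30000 nM, expected to fall between 8000 nM and 120000 nM.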

Compound 3, half-maximal inhibitory concentration: 25000 nM
Estimate against measurement, compound 3: 1.2-fold (0.08 log units) above, and the stated range covers the measured number.
By their numbers in this assay, from the lowest: compounds 1 and 3 (each within the scatter of the next); then compound 2.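

In this assay, within the data shown here, trimming the 3-chloropropyl tail to ethyl gives a 1.8-fold higher number from compound 1 to compound 3 (0.25 log units; within the scatter), so at this position the loss of the chloromethyl, which carries the only halogen in compound 1, cannot be told apart from the ordinary spread of repeated measurements. This tail end therefore accepts a chlorine-free, shorter chain without a clear shift in the number, whereas the change at the other end of the molecule, with a 3.6-fold higher number from compound 1 to compound 2 (0.56 log units; beyond the scatter), remains the only step shown that lies beyond the scatter. Nothing measured here offers an explanation for this result.

Compound 3 loses both the chlorine and part of the chain at once, and a propyl tail on the same core would separate those two changes. Going by these compounds, a longer chain or an amine at the end of the tail remains open, as does whether the ethyl tail would give a similar result when paired with the 4-hydroxyphenyl group of compound 2.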